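The source may hold more compounds than are shown below. What is called first, only, known or untested is meant among the compounds shown, and "the series" means these compounds.

Notes on the proline nitrile series.

Compound 3 `N#C[C@@H]1CCCN1C(=O)[C@@H]1C[C@H](C(N)=O)CN1` has the lowest number of the three measured: in an assay on the whole organism (plasma, strain Sprague-Dawley) for inhibition of Dipeptidyl peptidase 4 (Rattus norvegicus), with a stated time of 6 h, at a dose of 1 mg/kg by the oral route (on this read-out lower numbers stand for less inhibition and higher numbers for more inhibition at the one dose given (going by the name of the read-out)), compound 3 gives 47%. Compound 1 `N#C[C@@H]1CCCN1C(=O)[C@@H]1C[C@H](C(=O)N2CCOCC2)CN1` gives 73% and compound 2 `N#C[C@@H]1CCCN1C(=O)[C@@H]1C[C@H](CO)CN1` gives 64%, so compound 3 trails both beyond the scatter, with a number 26 percentage points lower from compound 1 to compound 3 (beyond the scatter) and a number 17 percentage points lower from compound 2 to compound 3 (beyond the scatter).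

Compound 4 `N#C[C@@H]1CCCN1C(=O)[C@@H]1C[C@H](C(=O)N2CCC2)CN1` is the next member. Its difference from compound 3 is azetidin-1-yl in place of amino on a carbonyl carbon. Among the compounds with values here, of the measured steps, only the one from compound 1 to compound 3 concerns the carbonyl carbon in question, and there the loss of morpholin-4-yl in favour of amino cost a number 26 percentage points lower from compound 1 to compound 3 (beyond the scatter). Compound 4 moves back in the same direction, replacing amino with another cyclic group joined through its nitrogen, so a gain of similar size, beyond the scatter, is expected. Nothing is known about azetidin-1-yl itself in this series, so the range is kept wide.

The step from compound 3 to compound 4 is therefore estimated at a number 21 percentage points higher from compound 3 to compound 4 (beyond the scatter). Compound 4 is expected to reach 68%, within 52% to 82%.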

Compound 4, a percentage reported as inhibition, in the whole organism at one dose (the size of the read-out at that dose, not a potency): 77%
The estimate for compound 4 lay 9 percentage points below the measured number; the measured number falls inside the stated range.
By their numbers in this assay, from the lowest: compound 3; then compounds 2, 1 and 4 (each within the scatter of the next, the first and the last beyond it).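

On the carbonyl carbon, the value of a cyclic group joined through its nitrogen now rests on two such groups: in this assay, azetidin-1-yl in place of amino gives a number 30 percentage points higher from compound 3 to compound 4 (beyond the scatter), while azetidin-1-yl in place of morpholin-4-yl gives a number 4 percentage points higher from compound 1 to compound 4 (within the scatter), so this read-out does not separate the two groups. Against hydroxymethyl on the saturated ring carbon, (azetidin-1-yl)carbonyl gives a number 13 percentage points higher from compound 2 to compound 4 (beyond the scatter), so this amide lies on the opposite side of hydroxymethyl from carbamoyl. Nothing at hand accounts for these steps.

Going by these compounds, it remains open whether an open-chain dimethylamino group on the same carbonyl carbon would match the two cyclic groups or stay closer to amino. A pyrrolidin-1-yl or piperidin-1-yl group there, or a carboxylic acid on the saturated ring carbon, is equally unresolved.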